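The source may report more compounds than this note shows. Statements on the series, on what has been measured and on what is new or still open speak of the compounds shown alone.

Measured compounds:
compound 1 `CCCCN(C)c1nc(C(F)(F)F)ccc1CNC(=O)C(C)c1ccc(NS(C)(=O)=O)c(F)c1` gives 0.8 nM in a functional assay on CHO-K1 cells for antagonist activity at transient receptor potential cation channel subfamily V member 1 (Homo sapiens), read by FLIPR; on this read-out higher numbers stand for weaker inhibition and lower numbers for stronger inhibition
compound 2 `CC(C(=O)NCc1ccc(C(F)(F)F)nc1N1CCC(Cc2cc(F)cc(F)c2)CC1)c1ccc(NS(C)(=O)=O)c(F)c1` gives 0.4 nM
compound 3 `CC(C(=O)NCc1ccc(C(F)(F)F)nc1N1CCC(OC(=O)C(C)(C)C)CC1)c1ccc(NS(C)(=O)=O)c(F)c1` gives 2 nM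

Compound 1 stands second highest of the three numbers. Its nearest neighbour is compound 2, whose value lies within the scatter of compound 1, so no order between them can be read; compound 3 lies beyond the scatter on the higher side. Compound 4 `CC(C(=O)NCc1ccc(C(F)(F)F)nc1N1CCN(C2CCCCC2)CC1)c1ccc(NS(C)(=O)=O)c(F)c1` has not yet been measured. It differs from compound 1 in one place: 4-cyclohexylpiperazin-1-yl in place of butyl(methyl)amino on an aromatic carbon

For the measured compounds named here, only one measured step bears on this spot: a 5.0-fold higher number from compound 2 to compound 3 (0.70 log units; beyond the scatter). That step shows a modest shift when the group attached to the saturated ring changes, while the comparison of compound 1 with compound 2 shows that an open chain and a ring at this aromatic carbon give numbers within the scatter of each other. A ring at this position is therefore expected to be tolerated, and the step of a 1.3-fold higher number from compound 1 to compound 4 (0.10 log units; within the scatter) is expected to stay small. Compound 4 is estimated at 1 nM, with a range from 0.3 nM to 4 nM.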

Compound 4, inhibition constant: 21.6 nM
Compound 4: the middle estimate sits 22-fold (1.33 log units) below what was measured; measured number outside the range, above it.
By their numbers in this assay, from the lowest: compounds 2 and 1 (each within the scatter of the next); then compound 3; then compound 4.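

At this aromatic carbon next to the ring nitrogen, putting 4-cyclohexylpiperazin-1-yl in place of butyl(methyl)amino gives a 27-fold higher number from compound 1 to compound 4 (1.43 log units; beyond the scatter) in this assay, so this position does not accept every large group that contains a ring. Compound 2 also has a saturated ring attached here and gives 0.4 nM, which shows that a ring at this carbon does not by itself bring the weaker inhibition seen with compound 4. Nothing available here accounts for the gap, and the entering group differs in both its second ring nitrogen and its cyclohexyl ring.

From the compounds shown here alone, it remains open which of these two features matters. A 4-cyclohexylpiperidin-1-yl group, with carbon in place of the second ring nitrogen, or a 4-benzylpiperazin-1-yl group, with benzyl in place of cyclohexyl, would separate them.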